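The source may hold more compounds than are shown below. What is called first, only, known or untested is meant among the compounds shown, and "the series" means these compounds.

Measured so far in an ADME assay on MT4 cells (Homo sapiens) for cytotoxicity, read by MTT assay, with a stated time of 5 days; a higher number here means that more compound is tolerated, a lower number that less compound is tolerated:

- Compound 1 `N#Cc1ccc(Nc2nccc(C(O)c3ccc(-c4ccc(C#N)cc4)cc3F)n2)cc1`: 14300 nM
- Compound 2 `N#Cc1ccc(Nc2nccc([C@@H](O)c3ccc(-c4ccc(C#N)cc4)cc3F)n2)cc1`: 7500 nM
- Compound 3 `N#Cc1ccc(Nc2nccc([C@@H](O)c3c(F)cc(-c4ccc(C#N)cc4)cc3F)n2)cc1`: 8400 nM

Compound 3, at 8400 nM, cannot be ranked against the other two, since its gaps to compound 1 and to compound 2 both lie within the usual scatter of repeated measurements.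

Compound 4 `N#Cc1ccc(Nc2nccc(C(O)c3c(F)cc(-c4ccc(C#N)cc4)cc3F)n2)cc1` has not yet been measured. Its change from compound 3 is this: the two compounds have the same atoms and bonds; at least one stereo element is drawn with a configuration in one of them and without one in the other: 1 of 1 stereo elements differ; a stereocentre at a saturated chain carbon is drawn S in compound 3 and without a configuration in compound 4. Nothing is added or removed, and the only difference lies in how one stereocentre is drawn.

Among the compounds with values here, the closest precedent is a 1.9-fold lower number from compound 1 to compound 2 (0.28 log units; within the scatter). Within the data shown here, the only difference behind that step is the fact that one of compounds 1 and 2 is drawn with a defined configuration and the other without, at the place where they differ, so it is the same kind of change as the one at hand, run in the opposite direction. The other measured step, a 1.1-fold higher number from compound 2 to compound 3 (0.05 log units; within the scatter), adds a fluoro in place of hydrogen and also stays small, so the same stereo change may well behave similarly with the added fluoro present.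

Reversing the precedent points to a slightly higher number, though not to a shift beyond the scatter. The expected size of the move is a 1.4-fold higher number from compound 3 to compound 4 (0.15 log units; within the scatter). For compound 4 the estimated value in this assay is 12000 nM, with an expected range from 7000 nM to 20000 nM.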

Compound 4, half-maximal cytotoxic concentration: > 45500 nM
Compound 4: a limit, no number (the forecaster's own chance of this, stated with the estimate: 10%); at least 3.7-fold (0.57 log units) between middle value and limit.
By their numbers in this assay, from the lowest: compounds 2, 3 and 1 (each within the scatter of the next). At a limit, above all of these: compound 4.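

In this assay, compound 4 gives > 45500 nM, which is a limit of the assay and not a number. With the second fluoro present, how the stereocentre at the saturated chain carbon is drawn now goes with a change beyond the scatter, an at least 5.4-fold higher number from compound 3 to compound 4 (0.73 log units; beyond the scatter), whereas the same kind of difference without that fluoro stayed within the scatter, a 1.9-fold lower number from compound 1 to compound 2 (0.28 log units; within the scatter). Fluoro in place of hydrogen on an aromatic carbon likewise gives an at least 3.1-fold higher number from compound 1 to compound 4 (0.50 log units; beyond the scatter) among the compounds drawn without a configuration, although it made no difference beyond the scatter among those drawn S, so the size of this step depends on the compound that carries it: the same change on two cores in this assay, a 1.1-fold higher number (0.05 log units; within the scatter) from compound 2 to compound 3 and an at least 3.1-fold higher number (0.50 log units; beyond the scatter) from compound 1 to compound 4, at least 2.8-fold (0.45 log units) apart, beyond the scatter of two such steps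

The compounds shown leave open how a compound drawn with the opposite configuration at this carbon would behave, and how far the value of compound 4 lies past its limit. They also leave open whether chloro in place of the added fluoro, or an amine in place of the hydroxy group on the chain carbon, would keep the same split between the drawn forms.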